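The source may hold more compounds than are shown below. What is called first, only, known or untested is meant among the compounds shown, and "the series" means these compounds.

Within the data shown here, in an assay on membranes from HeLa cells for displacement of a labelled ligand from adenosine receptor A3 (Homo sapiens), read by scintillation counting, with a stated time of 180 min, tested at 1 uM (a lower number here means less inhibition, a higher number more inhibition at the concentration tested (going by the name of the read-out)), compound 2 `CC1=C(C(=O)OC2CCCCC2)C(c2cccs2)NC(=O)N1` gives 1%, the lowest of the two numbers so far; its nearest neighbour, compound 1 `CC1=C(C(=O)OC2CCCCC2)C(c2ccco2)NC(=O)N1`, gives 4%, and the step of a number 3 percentage points lower from compound 1 to compound 2 (within the scatter) lies within the scatter. Compound 3 `CC1=C(C(=O)OC2CCCCC2)C(c2ccsc2)NC(=O)N1` differs from compound 2 by thiophen-3-yl in place of thiophen-2-yl on a saturated ring carbon. Among the measured compounds shown here, the only measured step that bears on this, a swap of one five-membered aromatic ring for another on the saturated ring carbon, a number 3 percentage points lower from compound 1 to compound 2 (within the scatter), was within the scatter, so no step beyond the scatter is expected in this assay, a number 2 percentage points higher from compound 2 to compound 3 (within the scatter). Compound 3 is therefore estimated at 3%, within -6% to 12%.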

Compound 3, a percentage reported as inhibition, at one concentration (the size of the read-out at that concentration, not a potency): 1%
Estimate against measurement, compound 3: 2 percentage points above, and the stated range covers the measured number.
By their numbers in this assay, from the lowest: compounds 2, 3 and 1 (each within the scatter of the next).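

In this assay, moving the attachment point on the thiophene ring gives no change at the digits printed from compound 2 to compound 3 (within the scatter) and replacing furan-2-yl with thiophen-3-yl gives a number 3 percentage points lower from compound 1 to compound 3 (within the scatter) at this saturated ring carbon. Neither the choice of thiophene attachment point nor the choice among these three five-membered aromatic rings therefore produces a step beyond the scatter, and all three compounds show little inhibition at the concentration tested. No measured evidence offers an explanation for these numbers. Still open, on these data alone, is whether a phenyl ring, or a ring carrying an amine or a carboxylic acid, would give a higher number at this position.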